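Series notes: amino-to-anilino step on the shared core

The source may report more compounds than this note shows. Statements on the series, on what has been measured and on what is new or still open speak of the compounds shown alone.

Measured so far in an assay on isolated protein (strain Sprague-Dawley) for inhibition of Amine oxidase [flavin-containing] B (Rattus norvegicus), read by spectrophotometry, with a stated time of 5 min; on this read-out higher numbers stand for weaker inhibition and lower numbers for stronger inhibition:
compound 1 `COCOc1cc(=O)oc2cc(OCc3cccc(Cl)c3)ccc12` gives 100 nM;
compound 2 `Nc1cc(=O)oc2cc(OCc3cccc(Cl)c3)ccc12` gives 47.9 nM.

Within the data shown here, compound 2 stands at the lower of the two numbers in this assay, with the one measured step being a 2.1-fold lower number from compound 1 to compound 2 (0.32 log units; beyond the scatter).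

Compound 3 `O=c1cc(Nc2ccccc2)c2ccc(OCc3cccc(Cl)c3)cc2o1` is not yet measured. The change is phenyl in place of hydrogen on a nitrogen on an aromatic ring. Among the measured compounds shown here, no measured step bears on this change; the only step, amino in place of methoxymethoxy, touches a different part of the molecule. Any step in this assay is therefore uncertain in size and direction.

Estimated: compound 3 gives 100 nM (range 20 nM to 500 nM), a step of a 2.1-fold higher number from compound 2 to compound 3 (0.32 log units; beyond the scatter) that is expected, not measured.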

Compound 3, half-maximal inhibitory concentration: 9770 nM
The estimate for compound 3 lay 98-fold (1.99 log units) below the measured number; the measured number lies above the stated range.
By their numbers in this assay, from the lowest: compound 2; then compound 1; then compound 3.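

In this assay, putting phenyl on the nitrogen costs far more than any change seen before: a 200-fold higher number from compound 2 to compound 3 (2.31 log units; beyond the scatter). The anilino group also compares poorly with methoxymethoxy at this place on the shared core, with a 98-fold higher number from compound 1 to compound 3 (1.99 log units; beyond the scatter), so a small amino group and a methoxymethoxy group both sit far ahead of anilino. Nothing measured on these compounds accounts for the loss.

On these data alone, it remains open whether the loss is specific to phenyl or follows from any group on this nitrogen. A methyl or a benzyl on the nitrogen would bear on that question.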